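This account rests on a few compounds, and the source may have more. Where it says the series, first, only, none or still open, it means among the compounds named here.

Measured so far in a functional assay on MCF7 cells (Homo sapiens) for antiproliferative activity, read by MTT assay, with a stated time of 48 h; a lower number here means a stronger inhibitor, a higher number a weaker inhibitor:
compound 1 `COc1ccc(C(=O)/C=C/c2cccc(Br)c2Oc2c([N+](=O)[O-])cc(C(F)(F)F)cc2[N+](=O)[O-])cc1` gives 2.32 ug/mL
compound 2 `O=C(/C=C/c1cccc(Br)c1Oc1c([N+](=O)[O-])cc(C(F)(F)F)cc1[N+](=O)[O-])c1ccc(F)cc1` gives 6.01 ug/mL

Compound 2 holds the higher of the two numbers, which makes it the weaker inhibitor of the pair, and its gap to compound 1 lies beyond the scatter. The next structure, compound 3 `O=C(/C=C/c1cccc(Br)c1Oc1c([N+](=O)[O-])cc(C(F)(F)F)cc1[N+](=O)[O-])c1ccc(Cl)cc1`, departs from compound 2 by one substitution: chloro in place of fluoro on an aromatic carbon. Among the compounds with values here, the one measured step that bears on this is a 2.6-fold higher number from compound 1 to compound 2 (0.41 log units; beyond the scatter) and it is modest, with fluoro in place of methoxy on an aromatic carbon. Within the data shown here, no measured step exchanges one halogen for another, so the data do not fix a direction. A step no larger than that one is expected in this assay and it may well stay within the scatter, with a slight lean towards a lower number. The estimated step is a 1.2-fold lower number from compound 2 to compound 3 (0.08 log units; within the scatter) and a somewhat larger move either way cannot be excluded. Compound 3 is expected at 5 ug/mL with an estimated range of 2.2 ug/mL to 11 ug/mL on present evidence.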

Compound 3, half-maximal inhibitory concentration: 4.74 ug/mL
Compound 3: the middle estimate sits 1.1-fold (0.02 log units) above what was measured; low and high end bracket the measured number.
By their numbers in this assay, from the lowest: compound 1; then compounds 3 and 2 (each within the scatter of the next).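

Within the data shown here, this is the first halogen-for-halogen exchange on the 4-substituted phenyl ketone, and in this assay it gives a 1.3-fold lower number from compound 2 to compound 3 (0.10 log units; within the scatter), so at this place, para to a large group, fluoro and chloro are not told apart by the numbers. Set against methoxy, chloro gives a 2.0-fold higher number from compound 1 to compound 3 (0.31 log units; beyond the scatter), which points the same way as a 2.6-fold higher number from compound 1 to compound 2 (0.41 log units; beyond the scatter): compound 1 keeps the lowest number of the three, compound 2 and compound 3 both stand apart from it, and neither goes against this reading, although it rests on only these three compounds and on a single position. Nothing measured on these compounds accounts for the gap between methoxy and the two halogens.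

On these data alone, it remains open whether the advantage of compound 1 belongs to methoxy alone or would extend to other groups at this place, such as an amine, a hydroxyl, a longer chain such as ethoxy or a carboxylic acid. The three compounds also say nothing about how changes to the shared core, for example to the bromo group or the trifluoromethyl group, would read in this series.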